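Cyclopropyl for phenyl on the amine nitrogen

This account rests on a few compounds, and the source may have more. Where it says the series, first, only, none or still open, it means among the compounds named here.

- compound 1 `c1ccc(COc2ccc(OCCOCCNC3CCCC3)cc2)cc1` gives 24800 nM
- compound 2 `c1ccc(COc2ccc(OCCOCCNc3ccccc3)cc2)cc1` gives > 100000 nM as a limit

Compound 2 gives > 100000 nM as a limit and not a number. Compound 3 `c1ccc(COc2ccc(OCCOCCNC3CC3)cc2)cc1` carries the change cyclopropyl in place of phenyl on an amine nitrogen. Among the measured compounds shown here, one measured step bears on it: an at least 4.0-fold higher number from compound 1 to compound 2 (0.60 log units; beyond the scatter) with phenyl in place of cyclopentyl on an amine nitrogen. Compound 3 reverses that kind of change with a smaller non-aromatic ring. In a functional assay on SK-OV-3 cells (Homo sapiens) for inhibition, read by CCK-8 assay, with a stated time of 70 h (a higher number here means a weaker inhibitor, a lower number a stronger inhibitor), the expected step is an at least 2.8-fold lower number from compound 2 to compound 3 (0.45 log units; beyond the scatter) and points to a lower number. Compound 3 is estimated at 35000 nM within 12000 nM to 100000 nM as the expected range.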

Compound 3, half-maximal inhibitory concentration: 47200 nM
Beside the measured number, compound 3's estimate is 1.3-fold (0.13 log units) below it; low and high end bracket the measured number.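

In this assay, the change gives an at least 2.1-fold lower number from compound 2 to compound 3 (0.32 log units; beyond the scatter), so a second non-aromatic ring on the amine nitrogen, after the cyclopentyl of compound 1, gives a measurable number where phenyl gave only a limit. With a 1.9-fold higher number from compound 1 to compound 3 (0.28 log units; within the scatter), cyclopropyl and cyclopentyl are not separated at this position. Compound 2 stands as a limit, so the step from it has no upper size: the limit of > 100000 nM in this assay, at which 1 of the 3 values shown sits.

Open, from the compounds shown here alone, is whether a cyclohexyl or an open-chain isopropyl on the same amine nitrogen would fall with these two rings, and whether a benzyl group would behave like phenyl.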